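The compounds below may be only part of what the source reports. "The series", "measured", "known", "first", "only" and "open" are said of these compounds alone.

Measured compounds and their values in a functional assay on MCF7 cells (Homo sapiens) for inhibition, read by MTT assay, with a stated time of 48 h, tested at 30 ug/mL; on this read-out higher numbers stand for more inhibition of growth at the one concentration tested and lower numbers for less inhibition of growth:

Compound 1, `COc1cccc2c1OCN(c1ccc3oc(-c4ccccc4)cc(=O)c3c1)C2`: 67.8%
Compound 2, `O=c1cc(-c2ccccc2)oc2ccc(N3COc4ccccc4C3)cc12`: 68.5%
Compound 3, `O=c1cc(-c2ccccc2)oc2cc(N3COc4c(Cl)cc(Cl)cc4C3)ccc12`: 34.6%

Compound 1 stands second highest of the three numbers; compound 2 is nearest to it, and the gap between them is within the scatter. Among the measured compounds shown here, compound 3 is furthest away, with a gap beyond the scatter, but compound 3 also carries two chlorines and a different attachment of the shared core, so its value shows only that a dichlorinated variant sits well lower; no single step links it to compound 1.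

The change under study is bromo in place of methoxy on an aromatic carbon, giving compound 4, `O=c1cc(-c2ccccc2)oc2ccc(N3COc4c(Br)cccc4C3)cc12`. For the measured compounds named here, the one measured step that bears on it is a number 0.7 percentage points higher from compound 1 to compound 2 (within the scatter): removing the methoxy altogether left the number unchanged. Whether bromo at this place behaves like hydrogen or pulls the number down, as the dichloro pattern of compound 3 might hint, is not shown. The expectation is therefore a small downward step, a number 7.8 percentage points lower from compound 1 to compound 4 (within the scatter), with a wide range. Compound 4 is estimated at 60%, between 40% and 75%.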

Compound 4, percent growth inhibition at one concentration: 71.6%
Compound 4: the middle estimate sits 11.6 percentage points below what was measured; low and high end bracket the measured number.
By their numbers in this assay, from the lowest: compound 3; then compounds 1, 2 and 4 (each within the scatter of the next).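

In this assay, the place on the aromatic carbon now carries three different substituents without a readable separation, with a number 3.8 percentage points higher from compound 1 to compound 4 (within the scatter) for bromo in place of methoxy and a number 3.1 percentage points higher from compound 2 to compound 4 (within the scatter) for bromo in place of hydrogen in these working notes. Compound 4 extends the earlier methoxy and hydrogen comparison to a halogen, and at this place a single bromo does not pull the number down. No measured data on the compounds offer an explanation for these numbers staying so close.

Going by these compounds, whether an amine, a carboxylic acid or a longer chain at this place would stay level with compound 4 remains open. Chloro alone at this place also remains open, and the single tested concentration cannot show whether compounds 1, 2 and 4 would separate at other concentrations.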